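Fluoro to methoxy on two related tricyclic cores

The compounds below may be only part of what the source reports. "The series", "measured", "known", "first", "only" and "open" are said of these compounds alone.

Measured compounds:
Compound 1, `COC(=O)[C@@]1(C)CCC=C2[C@@H]1CC[C@@H](C)[C@]2(C)Cc1c(C)[nH]c2ccc(F)cc12`, gives 11000 nM in a functional assay on HeLa cells (Homo sapiens) for inhibition, read by sulforhodamine B assay, with a stated time of 48 h; a higher number here means a weaker inhibitor of growth, a lower number a stronger inhibitor of growth.
Compound 2, `COC(=O)[C@@]1(C)CCC=C2[C@@H]1CC[C@@H](C)[C@]2(C)Cc1c(C)[nH]c2ccc(OC)cc12`, gives 12000 nM in this assay.
Compound 3, `COC(=O)[C@@]1(C)CC[C@@H]2C3=C1CC[C@@H](C)[C@]3(C)C[C@@H]1c3cc(F)ccc3N[C@H]21`, gives 20000 nM in this assay.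

Compounds 1 and 2 share one core and differ only by the change (methoxy in place of fluoro on an aromatic carbon). This change made a 1.1-fold higher number from compound 1 to compound 2 (0.04 log units; within the scatter), so the two values show no difference that the measurement can resolve. Compound 3 has a different core; the difference between the two cores is not broken down here. Its value stands nearest to compound 2 and furthest from compound 1, and both gaps are within the scatter, so none of the three compounds can be called stronger or weaker than another.

Compound 4, `COC(=O)[C@@]1(C)CC[C@@H]2C3=C1CC[C@@H](C)[C@]3(C)C[C@@H]1c3cc(OC)ccc3N[C@H]21`, is not yet measured. It arises from compound 3 through (methoxy in place of fluoro on an aromatic carbon). This is the same kind of change as that from compound 1 to compound 2, though not the same: the place in compound 1 is part of a fused or bridged system of two rings, whereas the place in compound 3 is part of a fused or bridged system of five rings, while in both cases the carbon is meta to a fused ring and para to a fused ring. Since the earlier step was a 1.1-fold higher number from compound 1 to compound 2 (0.04 log units; within the scatter), compound 4 is expected to sit close to compound 3, with an estimated step of a 1.1-fold higher number from compound 3 to compound 4 (0.04 log units; within the scatter). Compound 4 is therefore estimated at 22000 nM, with a likely range from 10000 nM to 48000 nM.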

Compound 4, concentration for 50% growth inhibition: 20000 nM
Compound 4: middle estimate off by 1.1-fold (0.04 log units), on the high side, within the range that was stated.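

In this assay, methoxy in place of fluoro on an aromatic carbon gave no change at the digits printed from compound 3 to compound 4 (within the scatter), so on the core of compound 3, as on the core of compound 1, the measurement resolves no difference between the two groups. Set side by side, the two steps agree: the same change on two cores in this assay, a 1.1-fold higher number (0.04 log units; within the scatter) from compound 1 to compound 2 and no change at the digits printed (within the scatter) from compound 3 to compound 4, 1.1-fold (0.04 log units) apart, within the scatter of two such steps. Among these compounds, this shows that, in this assay and on these two cores, the change carried over with no difference that can be resolved, but it rests on only two pairs and neither step lies beyond the scatter, so it does not show that a change with a measurable effect on one core would carry over to the other, or that the same would hold in any other assay.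

The compounds shown leave open whether a different group on this aromatic carbon, such as an amine, a carboxylic acid or a longer alkoxy chain, would separate from fluoro and methoxy in this assay. They also leave open whether the two cores would still track each other once a step of resolvable size appeared.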